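The compounds below may be only part of what the source reports. "The series", "measured", "known", "first", "only" and "open" are said of these compounds alone.

Three compounds share one core and were tested in a functional assay on the whole organism for inhibition, with Rattus norvegicus as the target, read by paw edema, at a dose of 100 mg/kg by the oral route; a higher number here means more inhibition at the dose given (going by the name of the read-out), a lower number less inhibition. Compound 1 `CNC(=O)c1c(O)c2cccnc2n(-c2ccccc2)c1=O` gives 9.6%. Compound 2 `O=C(NCc1ccccc1)c1c(O)c2cccnc2n(-c2ccccc2)c1=O` gives 1.6%, and compound 3 `O=C(NC1CCN(Cc2ccccc2)CC1)c1c(O)c2cccnc2n(-c2ccccc2)c1=O` gives 1.7%. On these numbers compound 2 has the lowest value of the three, yet its gaps to compound 1 and to compound 3 both lie within the scatter of repeated measurements, so no real order among them can be read.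

Compound 4 `COc1ccc(NC(=O)c2c(O)c3cccnc3n(-c3ccccc3)c2=O)cc1` is not yet measured. It differs from compound 2 in one place: 4-methoxyphenyl in place of benzyl on an amide-type nitrogen. Going by the values given here, the only measured step at a related position is a number 8 percentage points lower from compound 1 to compound 2 (within the scatter), which stayed within the scatter; no measured pair changes the same group that changes here. Among the compounds with values here, with every value so far low and every step within the scatter, a step of a number 2.4 percentage points higher from compound 2 to compound 4 (within the scatter) is expected in this assay, that is, none beyond the scatter. Compound 4 is therefore estimated at 4%, within a range from -5% to 14%.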

Compound 4, a percentage reported as inhibition, in the whole organism at one dose (the size of the read-out at that dose, not a potency): 0.3%
Estimate against measurement, compound 4: 3.7 percentage points above; low and high end bracket the measured number.
By their numbers in this assay, from the lowest: compounds 4, 2, 3 and 1 (each within the scatter of the next).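

In this assay, putting 4-methoxyphenyl in place of benzyl on the amide-type nitrogen gives a number 1.3 percentage points lower from compound 2 to compound 4 (within the scatter) and so does not separate the two groups, even though the new group brings an oxygen and a hydrogen-bond acceptor that benzyl lacks. Putting 4-methoxyphenyl in place of methyl at the same nitrogen gives a number 9.3 percentage points lower from compound 1 to compound 4 (within the scatter) and so does not separate those two groups either, which means that this position has now carried an aryl group, a benzyl group and a small alkyl group with no step beyond the scatter. No measurement at hand offers a reason for this flat picture.

From the compounds shown here alone, whether a carboxylic acid or a basic amine on a short chain at this nitrogen would lift the number beyond the scatter remains open. Also open, going by these compounds, is whether a group other than phenyl on the shared core would do so.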